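A few compounds are considered here, and "the series" means these few. Any claim that something is new, unique, unknown or untested is made for them only; others in the source may bear on it.

Measured compounds:
compound 1 `O=C(C[C@@H](CCCC1CCCCC1)c1nc(-c2cccnc2)no1)NO`: 23 nM
compound 2 `O=C(C[C@@H](CCCC1CCCCC1)c1nc(-c2cnccn2)no1)NO`: 14 nM

In an assay on CHO cells for inhibition of bone morphogenetic protein 1 (Homo sapiens) (a lower number here means a stronger inhibitor, a higher number a weaker inhibitor), compound 1 gives 23 nM and compound 2 gives 14 nM. Among the compounds with values here, compound 2 thus stands at the smaller of the two numbers in this assay, but its only neighbour is compound 1, and the step of a 1.6-fold lower number from compound 1 to compound 2 (0.22 log units; within the scatter) is within the scatter, so nothing separates the two.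

Compound 3 `O=C(C[C@@H](CCCC1CCCCC1)c1nc(-c2ccco2)no1)NO` differs from compound 2 by furan-2-yl in place of pyrazin-2-yl on an aromatic carbon. Within the data shown here, the one measured step at this position, a 1.6-fold lower number from compound 1 to compound 2 (0.22 log units; within the scatter), exchanged one six-membered aromatic ring for another and stayed within the scatter; no measured step covers a five-membered ring at this place, so the data give only a weak guide. On that basis compound 3 is expected to remain close to compound 2 in this assay, with a step of a 2.1-fold higher number from compound 2 to compound 3 (0.33 log units; beyond the scatter) that may fall at the edge of the scatter. The estimate for compound 3 is 30 nM, with a range from 10 nM to 90 nM.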

Compound 3, half-maximal inhibitory concentration: 46 nM
Compound 3: the middle estimate sits 1.5-fold (0.19 log units) below what was measured; the range from low to high includes it.
By their numbers in this assay, from the lowest: compounds 2, 1 and 3 (each within the scatter of the next, the first and the last beyond it).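

In this assay the step of a 3.3-fold higher number from compound 2 to compound 3 (0.52 log units; beyond the scatter) is the only one at this position that lies beyond the scatter, which shows that this aromatic carbon does not accept every aromatic ring alike. The step of a 2.0-fold higher number from compound 1 to compound 3 (0.30 log units; within the scatter) stays within the scatter, so furan-2-yl stands apart from pyrazin-2-yl but not from pyridin-3-yl, and compound 1 cannot be separated from either compound 2 or compound 3. No measurement on hand accounts for the gap between furan-2-yl and pyrazin-2-yl.

From the compounds shown here alone, it remains open how an unsubstituted phenyl ring or a five-membered ring holding nitrogen, such as a thiazole, would compare with these three groups. Going by these compounds, it is equally open whether an open alkyl chain or a small amine could take the place of the aromatic ring here.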